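This account rests on a few compounds, and the source may have more. Where it says the series, first, only, none or still open, it means among the compounds named here.

In a functional assay on HeLa cells (Homo sapiens) for antiproliferative activity, read by MTT assay, with a stated time of 3 days (on this read-out lower numbers stand for stronger inhibition and higher numbers for weaker inhibition), compound 1 (`Cc1ccc(C#Cc2cn(C/C=C\CN3C(=O)c4ccccc4C3=O)c(=O)[nH]c2=O)cc1`) gives > 100000 nM as its reading, which is a limit of the assay and not a number. Compound 2 (`O=C1c2ccccc2C(=O)N1C/C=C\Cn1cc(C#Cc2ccc(Br)cc2)c(=O)[nH]c1=O`) gives 87000 nM and compound 3 (`CCCCCCC#Cc1cn(C/C=C/CN2C(=O)c3ccccc3C2=O)c(=O)[nH]c1=O`) gives 34000 nM in the same test. Compound 3 therefore holds the lower of the two actual numbers, and its gap to compound 2 lies beyond the usual scatter.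

Compound 4 (`CCCCCC#Cc1cn(C/C=C/CN2C(=O)c3ccccc3C2=O)c(=O)[nH]c1=O`) differs from compound 3 in one place (hydrogen in place of methyl on a saturated chain carbon, five bonds along the chain from a triple-bonded carbon): hydrogen in place of methyl on a saturated chain carbon, five bonds along the chain from a triple-bonded carbon. Among the compounds with values here, only one measured step is available (an at least 1.1-fold lower number from compound 1 to compound 2 (0.06 log units; that floor lies within the scatter)) and it puts bromo in place of methyl on an aromatic carbon, so it offers little guidance for a change on a saturated chain. Within the data shown here, the better anchor is compound 3 at 34000 nM as the only measured compound with a saturated chain of this kind. The estimated change (a 1.1-fold higher number from compound 3 to compound 4 (0.05 log units; within the scatter)) is expected to stay within the scatter, with no clear direction. For compound 4 the expected value in this assay is 38000 nM with an estimated range of 15000 nM to 90000 nM on this read-out.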

Compound 4, half-maximal inhibitory concentration: 91000 nM
Estimate against measurement, compound 4: 2.4-fold (0.38 log units) below; measured number above the stated range.
By their numbers in this assay, from the lowest: compound 3; then compounds 2 and 4 (each within the scatter of the next). At a limit, above all of these: compound 1.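

Taking away one methyl from the saturated chain gives a 2.7-fold higher number from compound 3 to compound 4 (0.43 log units; beyond the scatter) in this assay, so inhibition weakens with this single change, made five bonds along the chain from a triple-bonded carbon. The only earlier step, an exchange on an aromatic carbon, had a floor within the scatter, so this is the first step shown that lies beyond it and the first to show that this chain is not a place where a small trim passes unnoticed. Within the data shown here, how much further the number could climb on this chain is hard to tell, since the readings in this test end in a limit, the one given by compound 1: the limit of > 100000 nM in this assay, at which 1 of the 4 values shown sits.

Going by these compounds, a single step gives a size for this one change, not a trend, so it remains open whether a longer chain would bring the number down further or whether the gain would stop at the length of compound 3. Also open, on these data alone, is how the test would respond to an amine or a carboxylic acid placed on this chain in place of the methyl.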